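Amino for dimethylamino, measured on one core, expected on another

A few compounds are considered here, and "the series" means these few. Any claim that something is new, unique, unknown or untested is made for them only; others in the source may bear on it.

Compound 1 `COc1ccc(C(=O)c2ccc(OC)c3c2OC(C)(C)C=C3)c(NC(=O)CN)c1` and compound 2 `COc1ccc(C(=O)c2ccc(OC)c3c2OC(C)(C)C=C3)c(NC(=O)CN(C)C)c1` share one core and differ only on the side chain. In a functional assay on HCT-8 cells (Homo sapiens) for antiproliferative activity, read by MTT assay, with a stated time of 48 h (on this read-out higher numbers stand for weaker inhibition and lower numbers for stronger inhibition), compound 1 gives 370 nM, while compound 2 gives 1590 nM. The change amino in place of dimethylamino on a saturated chain carbon bound to a carbonyl carbon yields a 4.3-fold lower number from compound 2 to compound 1 (0.63 log units; beyond the scatter).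

Compound 3 `COc1ccc(C(=O)c2cc(OC)c(OC)c(OC)c2)c(NC(=O)CN(C)C)c1` carries the dimethylamino side chain on a second core; the difference between the two cores is not broken down here. In this assay compound 3 gives 790 nM, which lies within the scatter of compound 2 and beyond the scatter of compound 1.

Compound 4 `COc1ccc(C(=O)c2cc(OC)c(OC)c(OC)c2)c(NC(=O)CN)c1` has not yet been measured. It stands to compound 3 as compound 1 stands to compound 2: amino in place of dimethylamino on a saturated chain carbon bound to a carbonyl carbon. The place is described in identical words for both pairs, so this is the same change, now made on the other core. For the measured compounds named here, only one measured instance of it exists, so the expectation rests on a single pair and on the assumption that the core of compound 3 carries the change as the core of compound 2 did, which nothing here shows.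

With that caution, compound 4 is expected to give 220 nM in this assay, with a likely range of 90 nM to 550 nM. The expected step of a 3.6-fold lower number from compound 3 to compound 4 (0.56 log units; beyond the scatter) is set slightly smaller than the measured one because a 4.3-fold lower number from compound 2 to compound 1 (0.63 log units; beyond the scatter) comes from a single pair.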

Compound 4, half-maximal inhibitory concentration: 330 nM
Estimate against measurement, compound 4: 1.5-fold (0.18 log units) below; the range from low to high includes it.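

In this assay, amino in place of dimethylamino on a saturated chain carbon bound to a carbonyl carbon again gives a step in the same direction on the second core, with a 2.4-fold lower number from compound 3 to compound 4 (0.38 log units; beyond the scatter). The steps on the two cores cannot be told apart in size, so in this series the change carries over from one core to the other both in direction and, within the resolution of these data, in magnitude: the same change on two cores in this assay, a 4.3-fold lower number (0.63 log units; beyond the scatter) from compound 2 to compound 1 and a 2.4-fold lower number (0.38 log units; beyond the scatter) from compound 3 to compound 4, 1.8-fold (0.25 log units) apart, within the scatter of two such steps

For the compounds shown here, this rests on only two matched pairs on two cores, so it does not establish a rule for further cores, does not prove that the two steps are identical in size, and gives no explanation of why the amino compounds have the lower numbers.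

The compounds shown leave open whether methylamino, a cyclic amine such as pyrrolidine, or a carboxylic acid at the same place would fall in line with amino or with dimethylamino. They also leave open whether a longer chain carrying the amino group would preserve the step on either core, and whether the step holds on cell lines other than the one tested here.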